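The compounds below may be only part of what the source reports. "The series", "measured", "known", "first", "only" and "open" are said of these compounds alone.

Working notes on the series. Compound 1 `Cc1cc(Oc2ccccc2)c(S(C)(=O)=O)cc1C(=O)N=C(N)N` gives 10 nM in a functional assay for inhibition of sodium/hydrogen exchanger (Oryctolagus cuniculus); on this read-out higher numbers stand for weaker inhibition and lower numbers for stronger inhibition. Going by the values given here, compound 2 `Cc1cc(-n2ccnc2)c(S(C)(=O)=O)cc1C(=O)N=C(N)N` gives 23 nM in this assay; the single measured step, a 2.3-fold higher number from compound 1 to compound 2 (0.36 log units; beyond the scatter), puts compound 2 at the higher of the two numbers so far, with compound 1 as its only neighbour.

Compound 3 `CS(=O)(=O)c1cc(C(=O)N=C(N)N)ccc1-n1ccnc1` is compound 2 with hydrogen in place of methyl on an aromatic carbon. Among the compounds with values here, no measured step touches this methyl group; the only step known, a 2.3-fold higher number from compound 1 to compound 2 (0.36 log units; beyond the scatter), changes a different substituent and is modest in size. Removal of a single carbon with no change in donors, acceptors or charge is therefore expected to give a small shift in this assay, if any, most likely towards a higher number, as a 1.7-fold higher number from compound 2 to compound 3 (0.24 log units; within the scatter). Compound 3 is estimated at 40 nM, with a range of 15 nM to 120 nM.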

Compound 3, half-maximal inhibitory concentration: 150 nM
Compound 3: the middle estimate sits 3.8-fold (0.57 log units) below what was measured; measured number above the stated range.
By their numbers in this assay, from the lowest: compound 1; then compound 2; then compound 3.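

In this assay, the methyl group on the aromatic carbon para to the methylsulfonyl group and meta to the 1H-imidazol-1-yl group counts for more than its single carbon suggests: hydrogen in its place gives a 6.5-fold higher number from compound 2 to compound 3 (0.81 log units; beyond the scatter). That step is larger than the only other one in the series, a 2.3-fold higher number from compound 1 to compound 2 (0.36 log units; beyond the scatter), so among the compounds shown a change at this carbon moves the number further than the exchange of phenoxy for 1H-imidazol-1-yl. Nothing available accounts for the size of this shift.

As far as these compounds go, whether methyl has the same weight with phenoxy in place of 1H-imidazol-1-yl stays open, since the pair rests on the 1H-imidazol-1-yl compounds alone. Also open, from the compounds shown here alone, is how an ethyl group, a chlorine atom or a methoxy group on this carbon would compare with methyl.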